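Aryl variation on the triazole nitrogen of the cinnamic acid series

A few compounds are considered here, and "the series" means these few. Any claim that something is new, unique, unknown or untested is made for them only; others in the source may bear on it.

Measured compounds:
compound 1 `COc1ccc(/C=C\C(=O)O)c(OCc2cn(-c3cccc(C#N)c3)nn2)c1CC=C(C)C`: 35300 nM
compound 2 `COc1ccc(-n2cc(COc3c(/C=C\C(=O)O)ccc(OC)c3CC=C(C)C)nn2)cc1`: 8700 nM
compound 3 `COc1ccc(/C=C\C(=O)O)c(OCc2cn(-c3nc4ccccc4s3)nn2)c1CC=C(C)C`: 16400 nM

All three share one core and differ only in the aromatic group on the triazole nitrogen. In a functional assay on HCT-116 cells (Homo sapiens) for cytotoxicity, read by MTT assay, with a stated time of 24 h (on this read-out higher numbers stand for weaker inhibition and lower numbers for stronger inhibition), compound 3, with its benzothiazolyl group, stands second highest of the three numbers; compound 2 is nearest, a 1.9-fold higher number from compound 2 to compound 3 (0.28 log units; within the scatter), and compound 1 furthest, a 2.2-fold lower number from compound 1 to compound 3 (0.33 log units; beyond the scatter). The step of a 4.1-fold lower number from compound 1 to compound 2 (0.61 log units; beyond the scatter) is the largest in the set.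

Compound 4 `COc1ccc(/C=C\C(=O)O)c(OCc2cn(-c3cccc([N+](=O)[O-])c3)nn2)c1CC=C(C)C` is not yet measured. Its change from compound 3: 3-nitrophenyl in place of 1,3-benzothiazol-2-yl on an aromatic nitrogen. Within the data shown here, no measured step exchanges benzothiazolyl for nitrophenyl directly. The closest analogue among the measured groups is the 3-cyanophenyl of compound 1, which gave the highest number. The steps of a 2.2-fold lower number from compound 1 to compound 3 (0.33 log units; beyond the scatter) and a 4.1-fold lower number from compound 1 to compound 2 (0.61 log units; beyond the scatter) show that moving away from 3-cyanophenyl lowered the number modestly; a return to a substituted phenyl of that kind is therefore expected to move compound 4 back toward compound 1, by a step of about a 1.5-fold higher number from compound 3 to compound 4 (0.18 log units; within the scatter) in this assay, possibly within the scatter. For compound 4 the expected value is 25000 nM, with a range of 10000 nM to 60000 nM.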

Compound 4, half-maximal inhibitory concentration: 27300 nM
For compound 4 the middle estimate is 1.1-fold (0.04 log units) below the measured one; the range from low to high includes it.
By their numbers in this assay, from the lowest: compounds 2, 3, 4 and 1 (each within the scatter of the next, the first and the last beyond it).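

In this assay, nitro in place of cyano gives a 1.3-fold lower number from compound 1 to compound 4 (0.11 log units; within the scatter), so 3-nitrophenyl and 3-cyanophenyl cannot be told apart at this triazole nitrogen, a comparison that compounds 1 to 3 alone could not make. 3-Nitrophenyl in place of 4-methoxyphenyl gives a 3.1-fold higher number from compound 2 to compound 4 (0.50 log units; beyond the scatter), beyond the scatter, so compound 2 now stands apart from two nitrogen-bound phenyl groups carrying nitrile or nitro, not from compound 1 alone. The exchange of 1,3-benzothiazol-2-yl for 3-nitrophenyl gives a 1.7-fold higher number from compound 3 to compound 4 (0.22 log units; within the scatter), within the scatter, so compound 3 is separated from neither compound 2 nor compound 4, and this group gives no clean break from either side of the set.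

No evidence in hand explains any of these differences. Still open, from the compounds shown here alone, is whether the separation of compound 2 follows from the methoxy group itself or would also appear with an unsubstituted phenyl, or with an amine or a hydroxyl group on the phenyl ring in its place.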